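Amide to urea on a sulfonate ester scaffold

A few compounds are considered here, and "the series" means these few. Any claim that something is new, unique, unknown or untested is made for them only; others in the source may bear on it.

Three compounds share a core in which an aryl sulfonate ester carries an acylated amino group. Compound 1 `CCCC(=O)Nc1ccc(S(=O)(=O)Oc2ccccc2C(C)C)cc1` gives 4900 nM in a functional assay on HT-29 cells (Homo sapiens) for antiproliferative activity, read by sulforhodamine B assay, with a stated time of 48 h; a lower number here means a stronger inhibitor, a higher number a weaker inhibitor. Among the compounds with values here, compound 2 `CC(C)c1ccccc1OS(=O)(=O)c1ccc(NC(=O)C(C)(C)C)cc1` gives 15000 nM, and the change a 3.1-fold higher number from compound 1 to compound 2 (0.49 log units; beyond the scatter) is the one measured step at the carbonyl carbon. Compound 3 `CC(C)(C)C(=O)Nc1ccc(S(=O)(=O)Oc2ccccc2I)cc1` gives 9500 nM; the step of a 1.6-fold lower number from compound 2 to compound 3 (0.20 log units; within the scatter) shows that swapping the aryl substituent did little. Among the three, compound 3 sits between the others, and both of its gaps fall within the scatter, so no order can be read from them.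

Compound 4 `O=C(Nc1ccc(S(=O)(=O)Oc2ccccc2I)cc1)NC1CC1` has not yet been measured. It differs from compound 3 by cyclopropylamino in place of tert-butyl on a carbonyl carbon, which turns the amide into a urea. Within the data shown here, no measured step covers this exact change. Among the measured compounds shown here, the only step at the same place is the one from a propyl to a tert-butyl group, which was modest, and the iodo-for-isopropyl step at the aromatic carbon was within the scatter. Compound 4 is therefore expected to stay near its parent, with the step of a 1.2-fold lower number from compound 3 to compound 4 (0.07 log units; within the scatter) estimated as small and of uncertain direction. The expected value for compound 4 is 8000 nM, within a range from 2500 nM to 25000 nM.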

Compound 4, half-maximal inhibitory concentration: 14000 nM
Estimate against measurement, compound 4: 1.8-fold (0.24 log units) below, within the range that was stated.
By their numbers in this assay, from the lowest: compounds 1, 3, 4 and 2 (each within the scatter of the next, the first and the last beyond it).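

In this assay, replacing tert-butyl with cyclopropylamino on the carbonyl carbon, which turns the amide into a urea, gives a 1.5-fold higher number from compound 3 to compound 4 (0.17 log units; within the scatter) and so does not separate the two compounds. Within the data shown here, until now, every group measured at this place was a plain carbon chain, so this is the first reading with a nitrogen attached to the carbonyl carbon and with a ring in the group. The swap keeps the count of heavy atoms and adds one hydrogen-bond donor, yet on the core carrying iodo these differences produce no step beyond the usual scatter, and nothing available explains this result.

A single urea cannot show whether the position stays this flat for other groups on the same carbonyl carbon, such as dimethylamino, phenylamino or a longer chain like n-butylamino. From the compounds shown here alone, it also remains open whether cyclopropylamino would give a similarly small step on the core carrying isopropyl, or against propyl instead of tert-butyl as the starting group.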